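The compounds below may be only part of what the source reports. "The series", "measured", "known", "first", "only" and "open" are said of these compounds alone.

Compound 1 `O=c1[nH]cc(S(=O)(=O)Nc2cccc(-c3cn(-c4ccccc4Cl)nn3)c2)c(=O)[nH]1` gives 14000 nM in an ADME assay on GES1 cells (Homo sapiens) for cytotoxicity, read by MTT assay, with a stated time of 24 h; a lower number here means that less compound is tolerated, a higher number that more compound is tolerated. Compound 2 `O=c1[nH]cc(S(=O)(=O)Nc2cccc(-c3cn(-c4cccc(Cl)c4)nn3)c2)c(=O)[nH]1` carries the change 3-chlorophenyl in place of 2-chlorophenyl on an aromatic nitrogen and gives 26200 nM; the step of a 1.9-fold higher number from compound 1 to compound 2 (0.27 log units; within the scatter) is small. Compound 3 `O=c1[nH]cc(S(=O)(=O)Nc2ccc(-c3cn(-c4ccccc4Cl)nn3)cc2)c(=O)[nH]1` has a different core from compound 1, and the difference between the two cores is not broken down here; in this assay compound 3 gives 16400 nM, close to compound 1 and compound 2. Compound 4 `O=c1[nH]cc(S(=O)(=O)Nc2ccc(-c3cn(-c4cccc(Cl)c4)nn3)cc2)c(=O)[nH]1` is related to compound 3 by 3-chlorophenyl in place of 2-chlorophenyl on an aromatic nitrogen, the same change as between compound 1 and compound 2, made at the same kind of place. Because the measured step of a 1.9-fold higher number from compound 1 to compound 2 (0.27 log units; within the scatter) stayed within the scatter, a step of similar size is expected, a 1.7-fold higher number from compound 3 to compound 4 (0.23 log units; within the scatter). Compound 4 is therefore estimated at 28000 nM, between 14000 nM and 56000 nM.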

Compound 4, half-maximal cytotoxic concentration: 7570 nM
Beside the measured number, compound 4's estimate is 3.7-fold (0.57 log units) above it; the measured number lies below the stated range.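

In this assay, on the core of compound 3, 3-chlorophenyl in place of 2-chlorophenyl gives a 2.2-fold lower number from compound 3 to compound 4 (0.34 log units; beyond the scatter). The same change therefore does not carry over with the same result between these two cores, so a step measured on one core is a poor guide to the other here: the same change on two cores in this assay, a 1.9-fold higher number (0.27 log units; within the scatter) from compound 1 to compound 2 and a 2.2-fold lower number (0.34 log units; beyond the scatter) from compound 3 to compound 4, 4.1-fold (0.61 log units) apart, beyond the scatter of two such steps. This rests on a single pair of compounds per core, and it does not show why the two steps differ or how the change would behave on any further core.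

The compounds shown leave open what other groups on the aromatic nitrogen would do on either core, such as a plain phenyl or a pyridine ring.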